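Phenyl for naphthyl on the imide nitrogen

The source may hold more compounds than are shown below. What is called first, only, known or untested is meant among the compounds shown, and "the series" means these compounds.

Three compounds of this series have been run in a functional assay on K562 cells (Homo sapiens) for antiproliferative activity, read by MTT assay, with a stated time of 48 h; a lower number here means a stronger inhibitor, a higher number a weaker inhibitor. Compound 1 `CN(C)CCCn1nc(C2=C(c3cn(C)c4ccccc34)C(=O)N(c3ccccc3)C2=O)c2cccnc21` gives 1700 nM. Compound 2 `Cn1cc(C2=C(c3nn(CCCN4CCCCC4)c4ncccc34)C(=O)NC2=O)c2ccccc21` gives 5960 nM. Compound 3 `Cn1cc(C2=C(c3nn(CCCN4CCCCC4)c4ncccc34)C(=O)N(c3cccc4ccccc34)C2=O)c2ccccc21` gives 3180 nM; its number sits between those of compound 1 and compound 2, and both of those lie within the scatter of it, so no order among the three can be claimed.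

The next compound, compound 4 `Cn1cc(C2=C(c3nn(CCCN4CCCCC4)c4ncccc34)C(=O)N(c3ccccc3)C2=O)c2ccccc21`, is reached from compound 3 by phenyl in place of naphthalen-1-yl on an amide-type nitrogen in a ring. Among the compounds with values here, the only measured step at the same place is a 1.9-fold lower number from compound 2 to compound 3 (0.27 log units; within the scatter), which stayed within the scatter. Compound 1 carries the same phenyl group on that nitrogen as compound 4 but differs from it elsewhere, so its value bears on the step only loosely; it does, however, sit within the scatter of compound 3 as well. Nothing in the measured compounds points to a change beyond the scatter in this assay for a swap of naphthalen-1-yl for phenyl.

For compound 4 the expected step is therefore a 1.3-fold lower number from compound 3 to compound 4 (0.10 log units; within the scatter), no larger than the scatter. Compound 4 is estimated at 2500 nM in this assay, with a range from 1200 nM to 5200 nM.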

Compound 4, half-maximal inhibitory concentration: 3790 nM
Compound 4: the middle estimate sits 1.5-fold (0.18 log units) below what was measured; measured number inside the range.
By their numbers in this assay, from the lowest: compounds 1, 3, 4 and 2 (each within the scatter of the next, the first and the last beyond it).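

In this assay, the phenyl and naphthalen-1-yl groups on the amide-type nitrogen give a 1.2-fold higher number from compound 3 to compound 4 (0.08 log units; within the scatter), and replacing hydrogen with phenyl at that nitrogen gives a 1.6-fold lower number from compound 2 to compound 4 (0.20 log units; within the scatter). Hydrogen, phenyl and naphthalen-1-yl therefore form a closed set of steps at this position, none beyond the scatter, so neither aromatic group separates from hydrogen or from the other in these compounds, even though the group entering at compound 4 has one carbon-only aromatic ring and the group leaving has two. Within the data shown here, with phenyl held constant on that nitrogen, the only new step beyond the scatter lies at another place, on the saturated chain carbon three bonds along the chain from an aromatic nitrogen, where piperidin-1-yl in place of dimethylamino gives a 2.2-fold higher number from compound 1 to compound 4 (0.35 log units; beyond the scatter), a modest change resting on a single pair. No supporting data bear on these steps.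

Still open, from the compounds shown here alone, is whether a benzyl group or a chain ending in a carboxylic acid on the amide-type nitrogen would move the number beyond the scatter. Also open, going by these compounds, are whether morpholin-4-yl at the chain end would do so, and whether the dimethylamino-for-piperidin-1-yl step holds with hydrogen or naphthalen-1-yl on the nitrogen.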